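This account rests on a few compounds, and the source may have more. Where it says the series, first, only, none or still open, it means among the compounds named here.

Four compounds share a sugar-bearing core and differ in the group attached to it and in the core itself. Compound 1 is `CNc1ncnc2c1c(-c1ccoc1)cn2[C@@H]1O[C@H](CO)[C@@H](O)[C@H]1O` and compound 2 is `CNc1ncnc2c1c(-c1cc3ccccc3o1)cn2[C@@H]1O[C@H](CO)[C@@H](O)[C@H]1O`. Compound 3 is `Nc1nc(N)c2c(-c3ccoc3)cn([C@@H]3O[C@H](CO)[C@@H](O)[C@H]3O)c2n1`, and compound 4, which has not yet been measured, is `Nc1nc(N)c2c(-c3cc4ccccc4o3)cn([C@@H]3O[C@H](CO)[C@@H](O)[C@H]3O)c2n1`. The difference between the core of compound 1 and the core of compound 3 is not broken down here.

In an ADME assay on MRC5 cells (Homo sapiens), read by MTT assay, with a stated time of 72 h (a lower number here means a stronger inhibitor, a higher number a weaker inhibitor), compound 1 gives only a limit of the assay, > 100000 nM. In this assay compound 2 gives 75300 nM. The change from compound 1 to compound 2 is 1-benzofuran-2-yl in place of furan-3-yl on an aromatic carbon, and it produced an at least 1.3-fold lower number from compound 1 to compound 2 (0.12 log units; that floor lies within the scatter). In this assay compound 3 also gives only a limit, > 100000 nM. Two of the three measured values sit at the same limit, (the limit of > 100000 nM in this assay, at which 2 of the 3 values shown sit), so what is known of this change rests on a single measured step.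

The change from compound 3 to compound 4 is 1-benzofuran-2-yl in place of furan-3-yl on an aromatic carbon, the same change as from compound 1 to compound 2, at the same place. Since compound 3 starts at a limit, any expected step has to be read from compound 1 and compound 2. In this assay the step this estimate means is an at least 1.2-fold lower number from compound 3 to compound 4 (0.09 log units; that floor lies within the scatter), expected to be small because an at least 1.3-fold lower number from compound 1 to compound 2 (0.12 log units; that floor lies within the scatter) was itself at the floor of what could be told apart from scatter. Compound 4 is therefore expected to give roughly 80000 nM, most likely between 40000 nM and 150000 nM, with a real chance that only a limit is reported again.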

Compound 4, half-maximal inhibitory concentration: 78500 nM
For compound 4 the middle estimate is 1.0-fold (0.01 log units) above the measured one; the measured number falls inside the stated range.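

In this assay, putting 1-benzofuran-2-yl in place of furan-3-yl on the core of compound 3 gives an at least 1.2-fold lower number from compound 3 to compound 4 (0.10 log units; that floor lies within the scatter), and the comparison with the same change on the core of compound 1 stands as follows: the same change on two cores in this assay, an at least 1.3-fold lower number (0.12 log units; that floor lies within the scatter) from compound 1 to compound 2 and an at least 1.2-fold lower number (0.10 log units; that floor lies within the scatter) from compound 3 to compound 4; the limit leaves it open whether they differ This shows that the two cores share one simple feature: compound 1 and compound 3, which carry furan-3-yl, stop at a limit of the assay, whereas compound 2 and compound 4, which carry 1-benzofuran-2-yl, give measured numbers, and the limit affects much of this small set: the limit of > 100000 nM in this assay, at which 2 of the 4 values shown sit. It does not show the true size of the step on either core, that the step is larger than the usual scatter, or that it carries over from one core to the other with the same size.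

The change also alters two things at once, the point at which the furan ring is attached and the presence of a fused six-membered aromatic ring, so a furan-2-yl group would be needed to tell these apart. On these data alone, it also remains open whether an amine or a carboxylic acid on the same aromatic carbon would give a number clearly lower than those seen here, on either core.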